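The source may report more compounds than this note shows. Statements on the series, on what has been measured and on what is new or still open speak of the compounds shown alone.

Compounds measured so far in an assay on HeLa cells for displacement of a labelled ligand from 5-hydroxytryptamine receptor 6 (Homo sapiens); on this read-out lower numbers stand for stronger inhibition and higher numbers for weaker inhibition:

Compound 1 `CCOc1nc2ccccn2c(=N)c1S(=O)(=O)c1ccccc1`: 12 nM
Compound 2 `C[S+]([O-])c1nc2ccccn2c(=N)c1S(=O)(=O)c1ccccc1`: 250 nM

Compound 2 shows the highest number of the two, with compound 1 giving a markedly lower one. Compound 3 `CNc1nc2ccccn2c(=N)c1S(=O)(=O)c1ccccc1` differs from compound 2 by a group of 2 heavy atoms (1 carbon, 1 nitrogen; no ring) in place of a group of 3 heavy atoms (1 carbon, 1 oxygen, 1 sulfur; no ring), on an aromatic carbon. For the measured compounds named here, the one measured step, a 21-fold higher number from compound 1 to compound 2 (1.32 log units; beyond the scatter), bears on this change, since it shows how much the group now leaving raised the number. Removing that group is therefore expected to bring the number back down, a step of a 6.3-fold lower number from compound 2 to compound 3 (0.80 log units; beyond the scatter). Compound 3 is estimated at 40 nM, within a range from 10 nM to 160 nM.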

Compound 3, half-maximal inhibitory concentration: 2.4 nM
Estimate against measurement, compound 3: 17-fold (1.22 log units) above; measured number outside the range, below it.
By their numbers in this assay, from the lowest: compound 3; then compound 1; then compound 2.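

Putting methylamino on this aromatic carbon gives a 100-fold lower number from compound 2 to compound 3 (2.02 log units; beyond the scatter) in this assay, so the group at this position can move the number over a wide range. Methylamino also goes lower than ethoxy, which held the lowest number until now, with a 5.0-fold lower number from compound 1 to compound 3 (0.70 log units; beyond the scatter): a modest step, but beyond the scatter, so ethoxy did not mark the lowest number reachable here.

Nothing available explains why the number moves this way. Going by these compounds, it remains open whether an unsubstituted amino group or a longer amine such as ethylamino would go lower still.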